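A methyl-to-trifluoromethyl swap in a cytotoxicity series

The source may hold more compounds than are shown below. What is called first, only, known or untested is meant among the compounds shown, and "the series" means these compounds.

Three measured compounds share a core and differ only in the aryl group attached to it. Compound 1 `Cc1cccc(-c2nc3ccc(C)cc3c(=O)[nH]2)c1` carries a methyl group on that aryl ring. In a functional assay on T47D cells (Homo sapiens) for cytotoxicity, read by MTT assay, with a stated time of 2 days (a lower number here means a stronger inhibitor, a higher number a weaker inhibitor), compound 1 gives only the limit of the assay, > 50000 nM. Compound 3 `Cc1ccc2nc(-c3ccccc3C)[nH]c(=O)c2c1` also carries a methyl, and in this assay compound 3 likewise reaches only the limit, > 50000 nM. How the cores of compound 1 and compound 3 differ is not broken down here. Compound 2 `Cc1ccc2nc(-c3ccccc3C(F)(F)F)[nH]c(=O)c2c1` replaces that methyl with trifluoromethyl (trifluoromethyl in place of methyl on an aromatic carbon), and in this assay compound 2 again returns only the limit, > 50000 nM. The step that the two limits leave unreadable from compound 3 to compound 2 therefore cannot be read, because of the limit of > 50000 nM in this assay, at which 3 of the 3 values shown sit. Compound 4 `Cc1ccc2nc(-c3cccc(C(F)(F)F)c3)[nH]c(=O)c2c1` makes the same kind of change starting from compound 1 (trifluoromethyl in place of methyl on an aromatic carbon), though here the place is meta to a large group rather than ortho to it. For compound 4 the expected step is a step that the limit leaves unreadable from compound 1 to compound 4, resting on the fact that (the limit of > 50000 nM in this assay, at which 3 of the 3 values shown sit). Compound 4 is accordingly estimated at 60000 nM, with a limit rather than a number the most likely outcome.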

Compound 4, half-maximal inhibitory concentration: > 50000 nM
Compound 4: no number, only a limit (the forecaster's own chance of this, stated with the estimate: 85%); the middle value lies beyond the limit too.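

No new step can be read from compound 4: the change from compound 1 to compound 4 stays unsized, because neither compound gives a number, only a limit: the limit of > 50000 nM in this assay, at which 4 of the 4 values shown sit. The compounds shown leave open how methyl and trifluoromethyl on the aryl ring compare in this assay at any concentration that yields a number.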